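A few compounds are considered here, and "the series" means these few. Any claim that something is new, unique, unknown or untested is made for them only; others in the source may bear on it.

Measured so far:
compound 1 `O=C(CCSc1nc2cc(F)ccc2o1)N1CCCC1` — 115 mL/min/g
compound 2 `CN(C(=O)CCSc1nc2cc(Cl)ccc2o1)C1CCS(=O)(=O)C1` — 0.8 mL/min/g

In an ADME assay on microsomes from liver (Mus musculus) for metabolic stability, read by LC-MS, using NADPH, with a stated time of 45 min, tested at 0.5 uM (on this read-out higher numbers stand for fast clearance and lower numbers for slow clearance), compound 2 gives the lowest of the two numbers recorded, while compound 1 gives a far higher value, beyond the usual scatter. Compound 3 `CN(C)C(=O)CCSc1nc2cc(Cl)ccc2o1` is not yet measured. It differs from compound 2 in one place: methyl in place of 1,1-dioxothiolan-3-yl on an amide-type nitrogen. Among the measured compounds shown here, with no measured pair showing this change, the expected direction rests on the shared pattern alone, and the expected step of a 25-fold higher number from compound 2 to compound 3 (1.40 log units; beyond the scatter) is an estimate toward faster clearance, of a size that clears the scatter. Compound 3 is therefore expected to give about 20 mL/min/g, within 4 mL/min/g to 80 mL/min/g.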

Compound 3, intrinsic clearance in a liver preparation (reported as CLH), per the amount of preparation that the assay uses: 41.8 mL/min/g
The estimate for compound 3 lay 2.1-fold (0.32 log units) below the measured number; the range from low to high includes it.
By their numbers in this assay, from the lowest: compound 2; then compound 3; then compound 1.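

Replacing 1,1-dioxothiolan-3-yl with methyl on this amide-type nitrogen gives a 52-fold higher number from compound 2 to compound 3 (1.72 log units; beyond the scatter) in this assay. This shows that a change at this one position, with the rest of the molecule held the same, can shift clearance by a large amount; compound 1 and compound 2 differ in more than one place, so they could not show this. No measurement here gives a reason for the step.

Still open, as far as these compounds go, is how a cyclopentyl group or a hydroxyethyl chain on the same nitrogen would read. The compounds shown therefore cannot separate the role of the ring itself from that of its sulfur and oxygen atoms.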